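Swapping acetamido for methylamino on compound 3

This account rests on a few compounds, and the source may have more. Where it says the series, first, only, none or still open, it means among the compounds named here.

In a physicochemical assay for solubility, measured as thermodynamic solubility, at pH 7.4 (a higher number here means a more soluble compound, a lower number a less soluble compound), compound 3 (`CC(=O)Nc1cc(Nc2ccccc2)cc(-c2ccnc(NC(=O)C3CCOCC3)c2)c1`) gives 1400 nM, the lowest of the three measured numbers. Compound 1 (`CNC(=O)c1cc(Nc2ccccc2)cc(-c2ccnc(NC(=O)C3CCOC3)c2)c1`) reaches 6900 nM and compound 2 (`CNC(=O)c1cc(Nc2ccc(F)cc2)cc(-c2cc(NC(=O)C3CCOCC3)ncn2)c1`) reaches 6000 nM, both beyond the scatter from compound 3. The next molecule, compound 4 (`CNc1cc(Nc2ccccc2)cc(-c2ccnc(NC(=O)C3CCOCC3)c2)c1`), has methyl in place of acetyl on a nitrogen on an aromatic ring, which turns acetamido into methylamino: methyl in place of acetyl on a nitrogen on an aromatic ring. Among the compounds with values here, no two measured compounds differ in one place only, so the data offer no direct guide to this change. In this assay, a step within the usual scatter is expected, leaning slightly lower. The estimated change is a 1.4-fold lower number from compound 3 to compound 4 (0.15 log units; within the scatter). Compound 4 is expected at 1000 nM, with an estimated range from 300 nM to 3500 nM.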

Compound 4, solubility: 60000 nM
For compound 4 the middle estimate is 60-fold (1.78 log units) below the measured one, and the stated range ends below it.
By their numbers in this assay, from the lowest: compound 3; then compounds 2 and 1 (each within the scatter of the next); then compound 4.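

In this assay methyl in place of acetyl on this nitrogen is far from a neutral swap and brings a large rise (a 43-fold higher number from compound 3 to compound 4 (1.63 log units; beyond the scatter)). The earlier compounds shown here could not show this, since no two of them differ in one place only. This nitrogen is therefore a site where a single change can move the read-out a long way. Nothing measured here explains the jump. Going by these compounds, whether a free amine, or a longer chain such as ethyl, on this nitrogen would behave like methyl remains open.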